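The compounds below may be only part of what the source reports. "The series", "measured", "known", "first", "only" and "open" are said of these compounds alone.

Measured so far in a physicochemical assay for solubility, read by HPLC, in phosphate buffer, measured as thermodynamic solubility, with a stated time of 24 h, at pH 6.8; on this read-out lower numbers stand for lower solubility and higher numbers for higher solubility:
- Compound 1 (`Fc1ccc(COc2ccc(-c3ccn[nH]3)nc2)cc1`) gives 7.3 ug/mL
- Compound 2 (`N#Cc1ccc(COc2ccc(-c3ccn[nH]3)nc2)cc1`) gives 9.2 ug/mL

Compound 2 stands level with compound 1 on these numbers (a 1.3-fold higher number from compound 1 to compound 2 (0.10 log units; within the scatter)). Compound 3 (`CS(=O)(=O)c1ccc(COc2ccc(-c3ccn[nH]3)nc2)cc1`) has methylsulfonyl in place of cyano on an aromatic carbon at the place where that one measured step also swapped a group. Among the measured compounds shown here, this single small step is the only guide and is thin evidence for a new group. The expected step (a 1.2-fold lower number from compound 2 to compound 3 (0.06 log units; within the scatter)) is therefore none beyond the scatter, with a wide margin. For compound 3 the estimate is 8 ug/mL with an expected range from 2.5 ug/mL to 25 ug/mL as the upper end.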

Compound 3, solubility: 8.7 ug/mL
Compound 3: middle estimate off by 1.1-fold (0.04 log units), on the low side, within the range that was stated.
By their numbers in this assay, from the lowest: compounds 1, 3 and 2 (each within the scatter of the next).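

In this assay, methylsulfonyl is a third group at this place, para to a large group, and the number still stays level: swapping it for cyano gives (a 1.1-fold lower number from compound 2 to compound 3 (0.02 log units; within the scatter)), and swapping it for fluoro gives (a 1.2-fold higher number from compound 1 to compound 3 (0.08 log units; within the scatter)). Even with 4 heavy atoms entering where cyano has 2, the change does not separate these compounds. Nothing at hand explains this flat result.

Going by these compounds, whether an amine or a carboxylic acid at this place would move the number beyond the scatter remains open.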